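Capping an Aniline Amine: Expected Effect on Microsomal Stability

The source may report more compounds than this note shows. Statements on the series, on what has been measured and on what is new or still open speak of the compounds shown alone.

Compound 1 `Nc1cccc(-c2ccc3nccc(-c4ccncc4)c3n2)c1` was tested in an ADME assay on microsomes from liver (Mus musculus) for metabolic stability, read by LC-MS, using NADPH, with a stated time of 30 min, tested at 0.1 uM (a higher number here means that more of the compound is left, a lower number that less of the compound is left), and gives 54%. Among the three measured compounds it stands second highest: compound 3 `CS(=O)(=O)Nc1ccc2nccc(-c3ccncc3)c2n1` gives 95%, and compound 2 `NS(=O)(=O)c1cncc(-c2ccc3nccc(-c4cn[nH]c4)c3n2)c1` gives 2%. The only single-site step shown, a number 41 percentage points higher from compound 1 to compound 3 (beyond the scatter), swaps the whole 3-aminophenyl group for methanesulfonamido and so is only a loose guide to the change at hand. Compound 4 `CS(=O)(=O)Nc1cccc(-c2ccc3nccc(-c4ccncc4)c3n2)c1` carries methylsulfonyl in place of hydrogen on a nitrogen on an aromatic ring, that is, amino to methanesulfonamido. Among the measured compounds shown here, no measured pair isolates this change. A rise beyond the scatter is nevertheless expected for compound 4, a number 18 percentage points higher from compound 1 to compound 4 (beyond the scatter). The estimate for compound 4 is 72%, in a range from 52% to 90%.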

Compound 4, percent of the compound remaining: 50%
Beside the measured number, compound 4's estimate is 22 percentage points above it; the measured number lies below the stated range.
By their numbers in this assay, from the lowest: compound 2; then compounds 4 and 1 (each within the scatter of the next); then compound 3.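

Putting methylsulfonyl in place of hydrogen on a nitrogen on an aromatic ring gives a number 4 percentage points lower from compound 1 to compound 4 (within the scatter), so capping this amino group leaves the two compounds indistinguishable in this read-out. Carrying methanesulfonamido is therefore not enough on its own to reach the value of compound 3, 95%. Nothing shown here explains this result.

As far as these compounds go, it remains open whether another group on the same nitrogen, such as acetyl or the longer ethylsulfonyl, would behave the same way. From the compounds shown here alone, it is equally open which other part of compound 4 governs how much of it remains.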